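A benzyloxy swap after two readings at the limit

A few compounds are considered here, and "the series" means these few. Any claim that something is new, unique, unknown or untested is made for them only; others in the source may bear on it.

Compound 1 `Cc1cc(=O)c(O)c(Cc2ccc(Cl)cc2)o1` and compound 2 `Cc1cc(=O)c(O)c(Cc2ccc(C(F)(F)F)cc2)o1` share a core and differ in one group. In a functional assay on U-87MG ATCC cells for antiproliferative activity against U-87 MG (Homo sapiens), read by MTT assay (on this read-out higher numbers stand for weaker inhibition and lower numbers for stronger inhibition), compound 1 gives > 50000 nM, which is a limit and not a number. Compound 2 gives > 50000 nM, again only a limit. Both results therefore stand together: the limit of > 50000 nM in this assay, at which 2 of the 2 values shown sit. Going by the values given here, the one measured step, a step that the two limits leave unreadable from compound 1 to compound 2, cannot be sized, so it gives no measure of how far a change at this place moves the read-out.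

Compound 3 `Cc1cc(=O)c(O)c(Cc2ccc(OCc3ccccc3)cc2)o1` carries benzyloxy in place of trifluoromethyl on an aromatic carbon. With no readable step to build on, only a small move is expected. In this assay the expected step is an at least 1.2-fold lower number from compound 2 to compound 3 (0.09 log units; that floor lies within the scatter), towards stronger inhibition if it can be read at all. For compound 3 the estimated value is 40000 nM, with a range from 15000 nM to 50000 nM.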

Compound 3, half-maximal inhibitory concentration: > 50000 nM
Compound 3: no number, only a limit (the forecaster's own chance of this, stated with the estimate: 65%); middle value at least 1.2-fold (0.09 log units) away from the limit.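

Compound 3 gives a limit and not a number, so neither step to it, from compound 1 or from compound 2, can be read, and all three compounds stand together: the limit of > 50000 nM in this assay, at which 3 of the 3 values shown sit.

The compounds shown leave open whether any group at this place can bring a readable number in this assay and how large such a step would be.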